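Sulfonamide nitrogen substituents on a shared thiourea-quinoline core

The source may report more compounds than this note shows. Statements on the series, on what has been measured and on what is new or still open speak of the compounds shown alone.

Compound 1 `Nc1ccc(S(=O)(=O)Nc2ccnc3cc(C(F)(F)F)ccc23)cc1`: 29600 nM
Compound 2 `CC(=O)NS(=O)(=O)c1ccc(N/C(S)=N\c2ccnc3cc(C(F)(F)F)ccc23)cc1`: 28300 nM
Compound 3 `Cc1cc(NS(=O)(=O)c2ccc(N/C(S)=N\c3ccnc4cc(C(F)(F)F)ccc34)cc2)on1`: 27300 nM

In a functional assay on HT-1080 cells (Homo sapiens) for antiproliferative activity, read by sulforhodamine B assay, with a stated time of 48 h (a lower number here means a stronger inhibitor, a higher number a weaker inhibitor), compound 2 gives 28300 nM, with compound 3 nearest and compound 1 furthest; both gaps lie within the scatter, so the three numbers cannot be told apart. Compound 4 `O=S(=O)(Nc1nccs1)c1ccc(N/C(S)=N\c2ccnc3cc(C(F)(F)F)ccc23)cc1` differs from compound 2 in one place: 1,3-thiazol-2-yl in place of acetyl on a sulfonamide nitrogen. For the measured compounds named here, the only measured step that bears on this spot, a 1.0-fold lower number from compound 2 to compound 3 (0.02 log units; within the scatter), swapped the same acetyl for another five-membered aromatic ring and left the number unchanged. The expected step from compound 2 to compound 4 is therefore a 1.0-fold lower number from compound 2 to compound 4 (0.00 log units; within the scatter), nothing beyond the scatter. Compound 4 is estimated at 28000 nM in this assay, within a range of 14000 nM to 56000 nM.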

Compound 4, half-maximal inhibitory concentration: 27300 nM
Compound 4: the middle estimate sits 1.0-fold (0.01 log units) above what was measured; measured number inside the range.
By their numbers in this assay, from the lowest: compounds 3, 4, 2 and 1 (each within the scatter of the next).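

Putting 1,3-thiazol-2-yl in place of acetyl on a sulfonamide nitrogen gives a step within the scatter (a 1.0-fold lower number from compound 2 to compound 4 (0.02 log units; within the scatter)), and putting it in place of 3-methyl-1,2-oxazol-5-yl does the same (no change at the digits printed from compound 3 to compound 4 (within the scatter)). A second five-membered aromatic ring, this one holding sulfur, thus also leaves the reading in this assay unmoved, so these three groups cannot be told apart at this position. No measurement here explains why they read alike. Still open, from the compounds shown here alone, is whether any group on this nitrogen can shift the number. A carboxylic acid, an amine or a longer alkyl chain might read differently.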